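Spirocyclic amide series: capping the hydroxyethyl chain

The source may hold more compounds than are shown below. What is called first, only, known or untested is meant among the compounds shown, and "the series" means these compounds.

Compound 3 `O=C(CN1CN(c2ccccc2)C2(CCN(C(=O)c3ccc(C4CCCCC4)cc3)CC2)C1=O)NCCO` gives 2000 nM in an assay on HEK293 cells for displacement of a labelled ligand from NPC1-like intracellular cholesterol transporter 1 (Homo sapiens) (on this read-out lower numbers stand for stronger inhibition and higher numbers for weaker inhibition), the second highest of the three numbers available. Its nearest neighbour is compound 2 `CC(C)(C)c1ccc(C(=O)N2CCC3(CC2)C(=O)N(CC(=O)NCCO)CN3c2ccccc2)cc1` at 1000 nM; the step of a 2.0-fold higher number from compound 2 to compound 3 (0.30 log units; within the scatter) lies within the scatter. The furthest is compound 1 `CC(C)(C)OC(=O)NC1CCCN(C(=O)CN2CN(c3ccccc3)C3(CCN(C(=O)c4ccc(C5CCCCC5)cc4)CC3)C2=O)C1` at 4400 nM, beyond the scatter above compound 3.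

Compound 4 `CC(C)(C)OC(=O)NCCNC(=O)CN1CN(c2ccccc2)C2(CCN(C(=O)c3ccc(C4CCCCC4)cc3)CC2)C1=O` is not yet measured. It differs from compound 3 by (tert-butoxycarbonyl)amino in place of hydroxy on a saturated chain carbon, two bonds along the chain from an amide-type nitrogen. Among the compounds with values here, no measured step follows this exact change; the only measured step, between compound 2 and compound 3, concerns the aromatic substituent and bears on it indirectly at most. Compound 1 also carries a (tert-butoxycarbonyl)amino group, in a different setting, and its value of 4400 nM is the highest of the set; this is the only hint available.

On that basis a modest rise is expected: compound 4 is estimated at 3500 nM in this assay, with a range of 1200 nM to 10000 nM. The expected step of a 1.8-fold higher number from compound 3 to compound 4 (0.24 log units; within the scatter) is small and uncertain.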

Compound 4, half-maximal inhibitory concentration: 5500 nM
Compound 4: middle estimate off by 1.6-fold (0.20 log units), on the low side, and the stated range covers the measured number.
By their numbers in this assay, from the lowest: compounds 2 and 3 (each within the scatter of the next); then compounds 1 and 4 (each within the scatter of the next).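

Hydroxy at this position, on a saturated chain carbon two bonds along the chain from an amide-type nitrogen, can be replaced by (tert-butoxycarbonyl)amino, 8 heavy atoms in place of 1, with a 2.8-fold higher number from compound 3 to compound 4 (0.44 log units; beyond the scatter) in this assay. Within the data shown here, this step lies beyond the scatter, whereas the aromatic substituent change, a 2.0-fold higher number from compound 2 to compound 3 (0.30 log units; within the scatter), does not, so this is the first single change with a readable effect. The size of the step stays modest, and compound 4 still gives a measurable number in this assay. No data on hand explain the rise.

Open, as far as these compounds go, is whether a free amine, a methoxy group or a longer chain ending in hydroxy at this position would stay nearer to compound 3 or to compound 4. Also open, from the compounds shown here alone, is whether the same replacement on compound 2, with its tert-butyl group, would give a step of similar size.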